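A few compounds are considered here, and "the series" means these few. Any claim that something is new, unique, unknown or untested is made for them only; others in the source may bear on it.

For the measured compounds named here, in an in vitro ADME assay on microsomes from liver (Homo sapiens) for metabolic stability (a higher number here means faster removal of the compound, a lower number slower removal), compound 2 `Fc1ccccc1Cc1nc(-c2nc(C(F)(F)F)n[nH]2)n2ccccc12` gives 72 mL.min-1.g-1, the only true number so far. Compound 1 `Cc1ncc(Cc2nc(-c3nc(C(F)(F)F)n[nH]3)n3ccccc23)cn1` reads < 8 mL.min-1.g-1, which is a limit of the assay and not a number. Compound 3 `FC(F)(F)c1n[nH]c(-c2nc(Cc3cncnc3)c3ccccn23)n1` departs from compound 2 by pyrimidin-5-yl in place of 2-fluorophenyl on a saturated chain carbon bound to an aromatic carbon. Going by the values given here, one measured step bears on this change: 2-fluorophenyl replacing the 2-methylpyrimidin-5-yl of compound 1 at that same place gave an at least 9.0-fold higher number from compound 1 to compound 2 (0.95 log units; beyond the scatter), beyond the scatter. The entering pyrimidin-5-yl is close to the group in compound 1, so that step, read backwards, points to a large fall in this assay. The expected change is an 8.0-fold lower number from compound 2 to compound 3 (0.90 log units; beyond the scatter). For compound 3 the estimated value is 9 mL.min-1.g-1, with an expected range of 4 mL.min-1.g-1 to 22 mL.min-1.g-1.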

Compound 3, intrinsic clearance in microsomes: < 7 mL.min-1.g-1
Compound 3 gave a limit, no number; the forecaster's own chance of this, stated with the estimate: 50%; middle value at least 1.2-fold (0.10 log units) from the limit.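

In this assay, pyrimidin-5-yl in place of 2-fluorophenyl on a saturated chain carbon bound to an aromatic carbon gives an at least 10-fold lower number from compound 2 to compound 3 (1.01 log units; beyond the scatter). The earlier fall in this read-out came with 2-methylpyrimidin-5-yl at this place, and the present step shows that a large fall from compound 2 also occurs with the unsubstituted pyrimidin-5-yl, so it does not depend on that methyl. Compound 3 gives a limit of the assay and not a number: the limit of < 7 mL.min-1.g-1 in this assay, at which 1 of the 3 values shown sits.

From the compounds shown here alone, the step from compound 1 to compound 3, hydrogen in place of methyl on an aromatic carbon, cannot be read, so any effect of that methyl in this assay stays open. Also open, going by these compounds, is whether a single ring nitrogen, as in pyridin-3-yl, at this place would give a comparable fall from compound 2.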